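The source may hold more compounds than are shown below. What is called first, only, known or untested is meant among the compounds shown, and "the series" means these compounds.

Two compounds with the shared core have been examined so far in an ADME assay on A549 cells (Homo sapiens) for cytotoxicity, read by CellTiter-Glo; on this read-out lower numbers stand for higher toxicity in this test and higher numbers for lower toxicity in this test. Compound 1 `C#CCNCC(O)COc1ccc2c(C)c(Cc3ccccc3)c(=O)oc2c1` gives 95500 nM, while compound 2 `Cc1c(Cc2ccc(C(C)(C)C)cc2)c(=O)oc2cc(OCC(O)CN3CCC(C(N)=O)CC3)ccc12` gives 14700 nM, the lower of the two numbers, with compound 1 standing a clear way above it, a gap beyond the usual scatter. Compound 3 `COC(=O)c1ccc(Cc2c(C)c3ccc(OCC(O)CN4CCC(C(N)=O)CC4)cc3oc2=O)cc1` has not yet been run in this assay. It differs from compound 2 in one place: methoxycarbonyl in place of tert-butyl on an aromatic carbon. Among the measured compounds shown here, no measured pair shows this change, so its effect can only be guessed. Because compound 2 sits at 14700 nM and no comparable exchange has been measured, a modest step of a 2.0-fold higher number from compound 2 to compound 3 (0.31 log units; beyond the scatter) toward a higher number is expected for compound 3, though it may well stay within the scatter. On this basis compound 3 is estimated to give 30000 nM in this assay, within a range from 10000 nM to 90000 nM.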

Compound 3, half-maximal cytotoxic concentration: > 100000 nM
Compound 3 ended at the assay's limit (the forecaster's own chance of this, stated with the estimate: 10%); at least 3.3-fold (0.52 log units) between middle value and limit.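

In this assay, the position para to a large group on the aromatic ring now has its first reading: methoxycarbonyl in place of tert-butyl gives an at least 6.8-fold higher number from compound 2 to compound 3 (0.83 log units; beyond the scatter). Compound 3 gives > 100000 nM, a limit of the assay and not a number, so the step has a lower bound but no known size: the limit of > 100000 nM in this assay, at which 1 of the 3 values shown sits. The two groups count the same 4 heavy atoms, yet methoxycarbonyl brings 2 hydrogen-bond acceptors where tert-butyl has none, so an exchange with no change in heavy-atom count is enough here to move the read-out beyond the scatter.

The compounds shown leave open how a carboxylic acid, a primary amide or an amine at this position would read. They also leave open whether the same exchange would move the number as far on the side chain of compound 1.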